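Replacing 2-Nitrophenyl with 2,3-Dichlorophenyl in Compound 3

A few compounds are considered here, and "the series" means these few. Any claim that something is new, unique, unknown or untested is made for them only; others in the source may bear on it.

In a functional assay (aorta) with Oryctolagus cuniculus as the target (on this read-out lower numbers stand for stronger inhibition and higher numbers for weaker inhibition), compound 3 (`CC1=NC(C)=C(C(=O)OCCCN2C(=O)c3ccccc3S2(=O)=O)C(c2ccccc2[N+](=O)[O-])/C1=C(\O)OCC1CCCCO1`) gives 11.5 nM, the highest of three numbers, with compound 1 (`CC1=NC(C)=C(C(=O)OCCCN2C(=O)c3ccccc3S2(=O)=O)C(c2ccccc2[N+](=O)[O-])/C1=C(\O)OC(C)C`) at 1.2 nM and compound 2 (`COCCO/C(O)=C1\C(C)=NC(C)=C(C(=O)OCCCN2C(=O)c3ccccc3S2(=O)=O)C1c1ccccc1[N+](=O)[O-]`) at 2.7 nM. Compound 4 (`CC1=NC(C)=C(C(=O)OCCCN2C(=O)c3ccccc3S2(=O)=O)C(c2cccc(Cl)c2Cl)/C1=C(\O)OCC1CCCCO1`) differs from compound 3 in one place: 2,3-dichlorophenyl in place of 2-nitrophenyl on a saturated ring carbon. Among the measured compounds shown here, no measured step touches this group. All three alter a different place, the group on an oxygen: a 2.3-fold higher number from compound 1 to compound 2 (0.35 log units; beyond the scatter), a 4.3-fold higher number from compound 2 to compound 3 (0.63 log units; beyond the scatter) and a 9.6-fold higher number from compound 1 to compound 3 (0.98 log units; beyond the scatter). They show that modest steps occur among these compounds, but they give no direction for this swap, so no clear shift is expected. The expected step is a 1.2-fold lower number from compound 3 to compound 4 (0.06 log units; within the scatter). For compound 4 the estimated value is 10 nM, within a range from 2.5 nM to 40 nM.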

Compound 4, half-maximal inhibitory concentration: 4 nM
Compound 4: the middle estimate sits 2.5-fold (0.40 log units) above what was measured; the measured number falls inside the stated range.
By their numbers in this assay, from the lowest: compound 1; then compounds 2 and 4 (each within the scatter of the next); then compound 3.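

This is the only step shown at the saturated ring carbon, and in this assay 2,3-dichlorophenyl in place of 2-nitrophenyl gives a 2.9-fold lower number from compound 3 to compound 4 (0.46 log units; beyond the scatter). The 2-nitrophenyl group is therefore not required for a low number here, at least alongside the (oxan-2-yl)methyl group on the oxygen. No available evidence explains this step. Going by these compounds, it remains open whether the same swap would act alike with the isopropyl group of compound 1 or the 2-methoxyethyl group of compound 2. Also open, on these data alone, is how a plain phenyl or 2-chlorophenyl would read at this carbon.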